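A few compounds are considered here, and "the series" means these few. Any claim that something is new, unique, unknown or untested is made for them only; others in the source may bear on it.

Measured so far in an assay on HEK293 cells for inhibition of prostaglandin E2 receptor EP2 subtype (Rattus norvegicus); a higher number here means a weaker inhibitor, a lower number a stronger inhibitor:
compound 1, `CC(C)(C)c1ccc(CN(Cc2cccc(OCC(=O)O)c2)S(C)(=O)=O)cc1`, gives 792 nM
compound 2, `CCCCCC(O)CCCN(CCCCCC(=O)O)S(C)(=O)=O`, gives 910 nM
compound 3, `Cn1ccnc1CS(=O)(=O)N(Cc1ccc(C(C)(C)C)cc1)Cc1cccc(OCC(=O)O)c1`, gives 326 nM

Among these three, compound 1 stands at the second highest number in this assay. Compound 2 sits closest to it, and the two values lie within the usual scatter of each other, so no order between them can be read. Compound 3 lies furthest away: the step of a 2.4-fold lower number from compound 1 to compound 3 (0.39 log units; beyond the scatter) puts 1-methyl-1H-imidazol-2-yl in place of hydrogen on a saturated chain carbon bound to a sulfonyl sulfur, a different part of the shared core from the change considered here.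

Compound 4, `CC(C)(C)c1ccc(CN(Cc2cccc(CCC(=O)O)c2)S(C)(=O)=O)cc1`, differs from compound 1 in one place: 2-carboxyethyl in place of carboxymethoxy on an aromatic carbon. Going by the values given here, none of the measured steps alters this position, so the data give no direct guide to its effect. With nothing pointing in either direction, the expected step of a 1.0-fold higher number from compound 1 to compound 4 (0.00 log units; within the scatter) is no more than modest. For compound 4 the estimate in this assay is 800 nM, expected to lie between 300 nM and 2200 nM.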

Compound 4, half-maximal inhibitory concentration: 379 nM
For compound 4 the middle estimate is 2.1-fold (0.32 log units) above the measured one; the measured number falls inside the stated range.
By their numbers in this assay, from the lowest: compounds 3 and 4 (each within the scatter of the next); then compounds 1 and 2 (each within the scatter of the next).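

In this assay, going by these compounds alone, this position on the aromatic carbon, which no earlier step had touched, proves able to move the number: with 2-carboxyethyl in place of carboxymethoxy, the result is a 2.1-fold lower number from compound 1 to compound 4 (0.32 log units; beyond the scatter) and the change lies beyond the scatter. The two groups have the same number of heavy atoms and the same hydrogen-bond donor count, but the entering group has more carbon, less oxygen and fewer hydrogen-bond acceptors, so a modest step follows from an exchange that leaves the size of the group unchanged. No evidence on the origin of this step is at hand.

The compounds shown leave open how a longer chain such as 3-carboxypropyl would read at this position. They also leave open whether a tetrazole could stand in for the carboxylic acid on this side chain.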